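Two Aryl Swaps Across Two Related Cores

A few compounds are considered here, and "the series" means these few. Any claim that something is new, unique, unknown or untested is made for them only; others in the source may bear on it.

Compound 1 `CC(O)(CSc1ccc(F)cc1)C(=O)Nc1ccc(S(F)(F)(F)(F)F)cc1` and compound 2 `CC(O)(CSc1cccc(C(F)(F)F)c1)C(=O)Nc1ccc(S(F)(F)(F)(F)F)cc1` share one core and differ only by 3-(trifluoromethyl)phenyl in place of 4-fluorophenyl on a sulfur. In a functional assay on DU-145 cells (Homo sapiens) for antiproliferative activity, read by propidium iodide staining, with a stated time of 96 h (on this read-out higher numbers stand for weaker inhibition and lower numbers for stronger inhibition), compound 1 gives 25400 nM and compound 2 gives 26200 nM, a step of a 1.0-fold higher number from compound 1 to compound 2 (0.01 log units; within the scatter). Compound 3 `CC(O)(CS(=O)(=O)c1ccc(F)cc1)C(=O)Nc1cccc(S(F)(F)(F)(F)F)c1` gives 48800 nM in this assay; the difference between its core and that of compound 1 is not broken down here. Compound 4 `CC(O)(CS(=O)(=O)c1cccc(C(F)(F)F)c1)C(=O)Nc1cccc(S(F)(F)(F)(F)F)c1` differs from compound 3 by 3-(trifluoromethyl)phenyl in place of 4-fluorophenyl on a sulfonyl sulfur. Among the measured compounds shown here, this is the same kind of change as the one from compound 1 to compound 2, but not the same: there the place was on a sulfur, here it is on a sulfonyl sulfur. Since that earlier change produced a 1.0-fold higher number from compound 1 to compound 2 (0.01 log units; within the scatter), the step from compound 3 to compound 4 is expected to be a 1.0-fold higher number from compound 3 to compound 4 (0.01 log units; within the scatter), resting on that single pair alone. Compound 4 is therefore estimated at 50000 nM in this assay, with a likely range from 25000 nM to 100000 nM.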

Compound 4, half-maximal inhibitory concentration: 37300 nM
Compound 4: the middle estimate sits 1.3-fold (0.13 log units) above what was measured; low and high end bracket the measured number.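

In this assay, placing 3-(trifluoromethyl)phenyl where 4-fluorophenyl stood on a sulfonyl sulfur gives a 1.3-fold lower number from compound 3 to compound 4 (0.12 log units; within the scatter), so this step, like the earlier one on a sulfur, stays within the scatter. The two cores agree as far as two pairs can show: the same change on two cores in this assay, a 1.0-fold higher number (0.01 log units; within the scatter) from compound 1 to compound 2 and a 1.3-fold lower number (0.12 log units; within the scatter) from compound 3 to compound 4, 1.3-fold (0.13 log units) apart, within the scatter of two such steps. Among the compounds shown here, this shows only that the change left the read-out within the scatter on both cores; it does not show that a larger effect would carry over, nor can it separate the contributions of the ways in which the two cores differ.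

The compounds shown leave open whether the same swap would hold on a core with an amine in place of the hydroxyl. They also leave open how an aryl group carrying a carboxylic acid would compare with these two.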